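A few compounds are considered here, and "the series" means these few. Any claim that something is new, unique, unknown or untested is made for them only; others in the source may bear on it.

Compound 1 `O=C(NO)c1cccc(-c2cn([C@H]3C[C@@H](CO)N(CCCc4ccccc4)C3)nn2)c1` gives < 10% in an assay on Sf9 cells for inhibition of histone deacetylase 11 (Homo sapiens), read by fluorescence, tested at 0.5 uM (on this read-out lower numbers stand for less inhibition and higher numbers for more inhibition at the one concentration tested (going by the name of the read-out)), a limit of the assay.
Compound 2 `O=C(NO)c1cccc(-c2cn([C@H]3C[C@@H](CO)N(Cc4ccccc4)C3)nn2)c1` gives < 10% in this assay, again a limit.
Compound 3 `O=C(NO)c1cccc(-c2cn([C@H]3C[C@H](C(=O)O)N(CCCc4ccccc4)C3)nn2)c1` gives < 10% in this assay, also a limit.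

Compound 1 and compound 2 share a core and differ in one place: phenyl in place of phenethyl on a saturated chain carbon bound to an amine nitrogen in a ring. The step that the two limits leave unreadable from compound 1 to compound 2 cannot be read as a number, because of the limit of < 10% in this assay, at which 3 of the 3 values shown sit. Compound 3 carries a different core; the difference between the two cores is not broken down here. Compound 4 `O=C(NO)c1cccc(-c2cn([C@H]3C[C@H](C(=O)O)N(Cc4ccccc4)C3)nn2)c1` is not yet measured and stands to compound 3 as compound 2 stands to compound 1: phenyl in place of phenethyl on a saturated chain carbon bound to an amine nitrogen in a ring. The two changes sit at the same place and are the same change.

Since both compounds at the larger side chain and the one at the smaller side chain all sit at a limit, compound 4 is expected to sit at that limit as well, with the step that the limit leaves unreadable from compound 3 to compound 4 estimated to stay within the scatter. For compound 4 the estimated value in this assay is 5%, expected between 0% and 15%.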

Compound 4, a percentage reported as inhibition, at one concentration (the size of the read-out at that concentration, not a potency): < 10%
Compound 4 ended at the assay's limit; the forecaster's own chance of this, stated with the estimate: 85%; the middle value lies beyond the limit too.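

No step can be read from compound 3 to compound 4, as compound 4 sits at a limit just as compound 3 does, because of this: the limit of < 10% in this assay, at which 4 of the 4 values shown sit.

In this assay the compounds shown leave open whether the side chain or the core has any bearing on inhibition, as none of them gives a value clear of that limit.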